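Anilino-triazine series: tolerance on Vero cells

The source may hold more compounds than are shown below. What is called first, only, known or untested is meant among the compounds shown, and "the series" means these compounds.

Within the data shown here, compound 1 `Cc1ccccc1Nc1nc(N)nc(CSc2nnc(-c3ccncc3)n2-c2ccccc2)n1` is the only member of the series with a number in an ADME assay on Vero cells (Chlorocebus sabaeus) for cytotoxicity, read by resazurin assay, with a stated time of 3 days; a lower number here means that less compound is tolerated, a higher number that more compound is tolerated; in that assay compound 1 gives 1650 ug/mL. Compound 2 `COc1ccc(Nc2nc(N)nc(CSc3nnc(-c4ccccc4)n3-c3ccccc3)n2)cc1` has no number in this assay; the entry for compound 2 reads "not determined" (no result reported), so compound 2 stands nowhere on the measured scale and gives no anchor of its own. Compound 3 `Cc1ccccc1Nc1nc(N)nc(CSc2nnc(-c3ccccc3)n2-c2ccccc2)n1` is the next member to be measured in this assay. The change from compound 2 to compound 3 is 2-methylphenyl in place of 4-methoxyphenyl on a nitrogen on an aromatic ring. Among the measured compounds shown here, no measured step exists for this change; without a number for compound 2, no direction can be read for this assay, and any shift is expected to stay within the scatter. Compound 3 is expected to be tolerated at about 1500 ug/mL, within a range of 500 ug/mL to 3000 ug/mL, because compound 1 gives 1650 ug/mL in this assay.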

Compound 3, half-maximal cytotoxic concentration: 1750 ug/mL
Beside the measured number, compound 3's estimate is 1.2-fold (0.07 log units) below it, within the range that was stated.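

In this assay the series now has its first readable step, a 1.1-fold higher number from compound 1 to compound 3 (0.03 log units; within the scatter), for phenyl in place of pyridin-4-yl on an aromatic carbon. Among these compounds, on this aromatic carbon, then, the two rings are not separated by the half-maximal cytotoxic concentration, and this holds for the one pair with 2-methylphenyl on the nitrogen. Nothing available bears on the reason for this result.

The step between compound 2 and compound 3 cannot be read, so the change from 4-methoxyphenyl to 2-methylphenyl on a nitrogen on an aromatic ring has no direction. Also open, from the compounds shown here alone, is whether an amine or a carboxylic acid in place of phenyl on that aromatic carbon would stay within the scatter as well.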